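Cytotoxicity notes on a chromone aryl ester pair

The source may hold more compounds than are shown below. What is called first, only, known or untested is meant among the compounds shown, and "the series" means these compounds.

Measured so far:
- compound 1 `COC(=O)c1cc(Cl)ccc1OC(=O)COc1cc(O)c2c(=O)cc(-c3ccccc3)oc2c1`: > 436000 nM
- compound 2 `COC(=O)c1ccc(Cl)cc1OC(=O)COc1cc(O)c2c(=O)cc(-c3ccccc3)oc2c1`: 265000 nM

In an ADME assay on cells (T-cell, Mus musculus, strain BALB/c) for cytotoxicity, read by MTT assay, with a stated time of 48 h (on this read-out higher numbers stand for lower toxicity in this test and lower numbers for higher toxicity in this test), compound 1 gives only a limit, > 436000 nM. Within the data shown here, compound 2 `COC(=O)c1ccc(Cl)cc1OC(=O)COc1cc(O)c2c(=O)cc(-c3ccccc3)oc2c1` gives 265000 nM in this assay, the single actual number in the set. Among the measured compounds shown here, the one step measured, an at least 1.6-fold lower number from compound 1 to compound 2 (0.21 log units; that floor lies within the scatter), is bounded by a limit, and its floor sits within the scatter, so it shows no clear change; the evidence behind it is the limit of > 436000 nM in this assay, at which 1 of the 2 values shown sits.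

Compound 3 `COC(=O)c1c(C)cccc1OC(=O)COc1cc(O)c2c(=O)cc(-c3ccccc3)oc2c1` is not yet measured. It differs from compound 2 by a group of 11 heavy atoms (9 carbon, 2 oxygen; one six-membered aromatic ring of carbon only) in place of a group of 11 heavy atoms (8 carbon, 2 oxygen, 1 chlorine; one six-membered aromatic ring of carbon only), on an oxygen next to a carbonyl group. For the measured compounds named here, no measured step covers this exchange; the only step in hand, from one chlorinated ring to another, gave no movement beyond the scatter. On that basis a step of no real size is expected, a 1.1-fold higher number from compound 2 to compound 3 (0.05 log units; within the scatter). For compound 3 the estimate in this assay is 300000 nM, with a range from 150000 nM to 600000 nM, and a fair chance that only a limit is returned.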

Compound 3, half-maximal cytotoxic concentration: 298000 nM
Estimate against measurement, compound 3: 1.0-fold (0.00 log units) above, within the range that was stated.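

In this assay, replacing the 5-chloro-2-(methoxycarbonyl)phenyl group on an oxygen next to a carbonyl group with a chlorine-free group of equal heavy-atom count gives a 1.1-fold higher number from compound 2 to compound 3 (0.05 log units; within the scatter), so removing chlorine from this aryl group produces no clear change between compound 2 and compound 3. Among these compounds, the earlier step compared only two chlorinated groups; this one extends the lack of clear movement to a group without chlorine, though only for this single exchange. The second new step, an at least 1.4-fold lower number from compound 1 to compound 3 (0.16 log units; that floor lies within the scatter), is bounded by a limit and also shows no clear change, and the evidence behind it is this limit for compound 1: the limit of > 436000 nM in this assay, at which 1 of the 3 values shown sits.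

Going by these compounds, whether compound 1 truly differs from compound 2 and compound 3 stays open, as does whether any aryl group at this place can move the number beyond the scatter. A carboxylic acid or an amine on the aryl group in place of the methoxycarbonyl group would test this, and the compounds shown give no reading on either.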